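The compounds below may be only part of what the source reports. "The series", "measured", "known", "first", "only" and "open" are said of these compounds alone.

Measured in an assay on HEK293 cells for positive allosteric modulation of metabotropic glutamate receptor 3 (Rattus norvegicus), read by thallium flux, with a stated time of 2.5 min; on this read-out higher numbers stand for larger maximal responses and lower numbers for smaller maximal responses:
compound 1 `Cc1c(OCCCCOc2ccc(C(=O)O)cc2)ccc(C(=O)CC(C)C)c1C`, 16.6%
compound 2 `Cc1c(OCCCCOc2ccc(C(=O)O)c(Cl)c2)ccc(C(=O)CC(C)C)c1C`, 12%
compound 3 `Cc1c(OCCCCOc2ccc(C(=O)O)c(Cl)c2)ccc(C(=O)CC(C)C)c1O`, 49.5%

Compound 2 gives the lowest of the three numbers. Going by the values given here, the step of a number 4.6 percentage points lower from compound 1 to compound 2 (within the scatter) is within the scatter, so compounds 1 and 2 cannot be told apart; the step of a number 37.5 percentage points higher from compound 2 to compound 3 (beyond the scatter) is beyond it and is the only large change seen in this assay.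

Compound 4 `Cc1c(OCCCCOc2ccc(C(=O)O)c(Cl)c2)ccc(C(=O)CC2CCCC2)c1C` differs from compound 2 by cyclopentyl in place of isopropyl on a saturated chain carbon bound to a carbonyl carbon. Among the compounds with values here, both measured steps alter a substituent on an aromatic carbon; neither touches the saturated chain carbon bound to the carbonyl carbon, so no measured step bears on this change. No step beyond the scatter is therefore expected in this assay. Compound 4 is expected to give 14%, with a range of 5% to 32%, an expected step of a number 2 percentage points higher from compound 2 to compound 4 (within the scatter).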

Compound 4, largest response reached (reported as percent of maximum), in percent of the reference or control that the assay uses: 35.5%
Estimate against measurement, compound 4: 21.5 percentage points below, and the stated range ends below it.
By their numbers in this assay, from the lowest: compounds 2 and 1 (each within the scatter of the next); then compound 4; then compound 3.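

The saturated chain carbon bound to a carbonyl carbon is not a silent place in this assay: cyclopentyl in place of isopropyl gives a number 23.5 percentage points higher from compound 2 to compound 4 (beyond the scatter), so the response can also shift beyond the scatter away from the aromatic substituents. Neither group carries a hydrogen-bond donor or acceptor, and the entering group brings a five-membered ring of carbon only. Nothing measured here accounts for the step.

Still open, as far as these compounds go, is whether cyclohexyl or a longer open chain at this place would give a similar step. Also open, from the compounds shown here alone, is how cyclopentyl behaves with hydroxy in place of methyl on the aromatic carbon, as in compound 3.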